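Swapping a sulfonamide for an aryl ester on the cyclohexyl ring

The compounds below may be only part of what the source reports. "The series", "measured", "known", "first", "only" and "open" are said of these compounds alone.

Measured so far:
compound 1 `Nc1cc(C(F)(F)F)cc2c(=O)cc(N3CCN(CC4CCCCC4)CC3)sc12`: 69.4%
compound 2 `CS(=O)(=O)NC1CCC(CN2CCN(c3cc(=O)c4cc(C(F)(F)F)cc([N+](=O)[O-])c4s3)CC2)CC1`: 111%
compound 3 `O=c1cc(N2CCN(CC3CCCCC3)CC2)sc2c(NO)cc(C(F)(F)F)cc12`: 47.8%

In an ADME assay on cells (Hepatocyte, Mus musculus) for metabolic stability, with a stated time of 30 min (a lower number here means that less of the compound is left, a higher number that more of the compound is left), compound 2 gives 111%, the highest of the three numbers. Its nearest neighbour is compound 1, which gives 69.4%, and the furthest is compound 3, which gives 47.8%; both gaps lie beyond the scatter.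

The unmeasured compound 4 `Cc1ccc(C(=O)OC2CCC(CN3CCN(c4cc(=O)c5cc(C(F)(F)F)cc([N+](=O)[O-])c5s4)CC3)CC2)cc1` differs from compound 2 in one place: ((4-methylphenyl)carbonyl)oxy in place of methanesulfonamido on a saturated ring carbon

Among the compounds with values here, the only measured step, a number 21.6 percentage points lower from compound 1 to compound 3 (beyond the scatter), concerns a hydroxy placed on an aromatic amine and has nothing in common with an ester replacing a methanesulfonamido on a saturated ring carbon. Within the data shown here, no measured pair therefore bears on this change, and any expectation must rest on compound 2 alone, which starts from 111%.

For compound 4 the expected result in this assay is 60%, within a broad range from 20% to 100%. Among the measured compounds shown here, this estimate means a step of a number 51 percentage points lower from compound 2 to compound 4 (beyond the scatter), and the width of the range reflects that no comparable step has been measured.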

Compound 4, percent of the compound remaining: 18%
For compound 4 the middle estimate is 42 percentage points above the measured one; the measured number lies below the stated range.
By their numbers in this assay, from the lowest: compound 4; then compound 3; then compound 1; then compound 2.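

In this assay, the group on this saturated ring carbon has a large influence on the result: with the rest of the molecule unchanged, ((4-methylphenyl)carbonyl)oxy in place of methanesulfonamido gives a number 93 percentage points lower from compound 2 to compound 4 (beyond the scatter). Within the data shown here, the earlier single-place step concerned only a nitrogen on an aromatic ring, so this is the first direct comparison showing that a change on the six-membered non-aromatic ring can also move the number. No measurement shown here gives a reason for this step.

The change replaces methanesulfonamido with an ester link and adds an aromatic ring, and the compounds shown do not separate these two parts. As far as these compounds go, it remains open how an amide carrying the same 4-methylphenyl ring, or a simple hydroxy group or amine on that ring carbon, would compare.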